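Ethyl for methyl on the amine nitrogen of compound 3

The compounds below may be only part of what the source reports. "The series", "measured", "known", "first", "only" and "open" are said of these compounds alone.

In an in vitro assay on 293-EBNA cells for binding affinity to corticotropin-releasing factor receptor 1 (Homo sapiens) (a lower number here means a stronger inhibitor, a higher number a weaker inhibitor), the three measured compounds stand as follows:
Compound 1, `Cc1nc(N2CCCCC2)c2nnn(-c3ccc(C(C)C)cc3Br)c2n1`: 46 nM
Compound 2, `CCC(COC)N(C)c1nc(C)nc2c1nnn2-c1ccc(C(C)C)cc1Br`: 11.2 nM
Compound 3, `COCC(COC)N(C)c1nc(C)nc2c1nnn2-c1ccc(C(C)C)cc1Br`: 21.3 nM

Compound 3 gives the second highest number of the three in this assay; its nearest neighbour is compound 2, with a 1.9-fold higher number from compound 2 to compound 3 (0.28 log units; within the scatter), and the furthest is compound 1, with a 2.2-fold lower number from compound 1 to compound 3 (0.33 log units; beyond the scatter). Both replacements of the ring amine of compound 1 by an open chain amine lowered the number, a 4.1-fold lower number from compound 1 to compound 2 (0.61 log units; beyond the scatter) and a 2.2-fold lower number from compound 1 to compound 3 (0.33 log units; beyond the scatter), while the exchange between the two open chain amines stayed within the scatter.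

Compound 4, `CCN(c1nc(C)nc2c1nnn2-c1ccc(C(C)C)cc1Br)C(COC)COC`, differs from compound 3 by methyl in place of hydrogen on a saturated chain carbon bound to a nitrogen on an aromatic ring. For the measured compounds named here, none of the measured steps alters this position, so no step bears directly on it; the closest guide is that the two open chain amines of compound 2 and compound 3 lie within the scatter of each other. Compound 4 is therefore expected to change little, a 1.1-fold lower number from compound 3 to compound 4 (0.03 log units; within the scatter), and its estimated value in this assay is 20 nM, with a range from 8 nM to 50 nM.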

Compound 4, inhibition constant: 123 nM
Beside the measured number, compound 4's estimate is 6.2-fold (0.79 log units) below it; the whole stated range lies below it.
By their numbers in this assay, from the lowest: compounds 2 and 3 (each within the scatter of the next); then compound 1; then compound 4.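

In this assay the methyl to ethyl change is the first step shown at this position, and it is not neutral (a 5.8-fold higher number from compound 3 to compound 4 (0.76 log units; beyond the scatter)), whereas the two open chain amines compared earlier stayed within the scatter of each other. The advantage of an open chain amine over the ring amine also disappears here (a 2.7-fold higher number from compound 1 to compound 4 (0.43 log units; beyond the scatter)), and the distance to the methoxy-bearing chain of compound 2 is large (an 11-fold higher number from compound 2 to compound 4 (1.04 log units; beyond the scatter)), so compound 4 is the weakest of the four and an open chain amine is not better in every case. No measurement shown here accounts for this loss.

From the compounds shown here alone, whether a longer chain such as propyl at this position would weaken binding further remains open. So does whether the same methyl to ethyl change would cost as much on the amine of compound 2.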